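The compounds below may be only part of what the source reports. "The series", "measured", "known", "first", "only" and "open" are said of these compounds alone.

In a functional assay for inhibition, with Rattus norvegicus as the target (on this read-out higher numbers stand for weaker inhibition and lower numbers for stronger inhibition), compound 1 `CC(C)/N=c1\c(O)c(O)\c1=N/c1ccc(C#N)cc1` gives 13700 nM. Compound 2 `Cc1ccc(C(C)/N=c2\c(O)c(O)\c2=N/c2ccc(C#N)cc2)cc1` is reported only as a limit, > 30000 nM. Compound 2 therefore stands at the limit of > 30000 nM in this assay, at which 1 of the 2 values shown sits, and no exact number is available for it.

Among the measured compounds shown here, the one measured step is an at least 2.1-fold higher number from compound 1 to compound 2 (0.34 log units; beyond the scatter). It came with 4-methylphenyl in place of methyl on a saturated chain carbon, which is the change that created the aromatic carbon now being altered.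

Compound 3 `CC(/N=c1\c(O)c(O)\c1=N/c1ccc(C#N)cc1)c1ccc(OC(F)(F)F)cc1` carries trifluoromethoxy in place of methyl on an aromatic carbon, para to a large group: trifluoromethoxy in place of methyl on an aromatic carbon. For the measured compounds named here, no measured step covers a change at this place, so the earlier step bears on it only indirectly, by showing where this series already lies in this assay. With only a limit as the starting point for compound 3, no clear move in either direction is expected, and a result again at the limit would be unsurprising. The expected change is a number no higher from compound 2 to compound 3 (the limit leaves the size open). For compound 3 the estimated value is 30000 nM, with an expected range of 12000 nM to 75000 nM.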

Compound 3, half-maximal inhibitory concentration: > 30000 nM
Compound 3 was reported as a limit; the forecaster's own chance of this, stated with the estimate: 65%; the middle value lies on the limit itself.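

Among the compounds shown here, compound 3, like compound 2, is reported in this assay only as a limit, so no step between compound 2 and compound 3 can be read: the limit of > 30000 nM in this assay, at which 2 of the 3 values shown sit. The compounds shown leave open where compound 2 and compound 3 actually stand, and whether trifluoromethoxy in place of methyl on the aromatic carbon changes inhibition at all.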